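Heteroaryl exchange on a hydroxamic acid chain

A few compounds are considered here, and "the series" means these few. Any claim that something is new, unique, unknown or untested is made for them only; others in the source may bear on it.

Measured so far:
compound 1 `O=C(CCCCCCC(=O)Nc1nnc(-c2cccs2)s1)NO` — 880 nM
compound 2 `O=C(CCCCCCC(=O)Nc1nnc(-c2ccc(Br)o2)s1)NO` — 880 nM

In a functional assay on MCF7 cells (Homo sapiens) for inhibition, read by MTT assay (on this read-out lower numbers stand for stronger inhibition and higher numbers for weaker inhibition), compound 2 gives 880 nM and stands level with compound 1 at the digits shown; the step of no change at the digits printed from compound 1 to compound 2 (within the scatter) lay within the scatter. Compound 3 `Cc1ccc(-c2nnc(NC(=O)CCCCCCC(=O)NO)s2)s1` differs from compound 2 by 5-methylthiophen-2-yl in place of 5-bromofuran-2-yl on an aromatic carbon. Going by the values given here, the only measured step that bears on this exchange, no change at the digits printed from compound 1 to compound 2 (within the scatter), also swapped one five-membered aromatic ring for another and brought no change beyond the scatter, so no step beyond the scatter is expected here either. Compound 3 is therefore estimated at 880 nM in this assay, between 400 nM and 2000 nM. The expected step is no change at the digits printed from compound 2 to compound 3 (within the scatter).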

Compound 3, half-maximal inhibitory concentration: 880 nM
The estimate for compound 3 equals the measured number at the digits printed; measured number inside the range.
By their numbers in this assay, from the lowest: compounds 1, 2 and 3 (each within the scatter of the next).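

In this assay, going by these compounds alone, methyl in place of hydrogen on an aromatic carbon of the thiophen-2-yl ring shows no change at the digits printed from compound 1 to compound 3 (within the scatter), the first step here that adds a substituent while the ring stays the same. Exchanging 5-bromofuran-2-yl for 5-methylthiophen-2-yl shows no change at the digits printed from compound 2 to compound 3 (within the scatter), so changing the ring hetero atom and the substituent together also leaves the reading unmoved. No supporting measurement bears on this result. From the compounds shown here alone, whether an amine or a carboxylic acid on this ring would move the value remains open, as does the effect of a longer chain.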